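Chloro for methoxy on the anilino ring of compound 2

The source may report more compounds than this note shows. Statements on the series, on what has been measured and on what is new or still open speak of the compounds shown alone.

Measured so far in a functional assay on the whole organism (strain Wister albino) for inhibition, with Rattus norvegicus as the target, read by paw edema, with stated times of 1 h and 2 h, at a dose of 50 mg/kg by the intraperitoneal route; a lower number here means less inhibition, a higher number more inhibition at the dose given (going by the name of the read-out):
compound 1, `CCOC(=O)c1c(-c2ccc(Cl)cc2)cc(-c2ccccc2)nc1N1CCN(C)CC1`, 39.6%
compound 2, `CCOC(=O)c1c(-c2ccc(Cl)cc2)cc(-c2ccccc2)nc1Nc1ccc(OC)cc1`, 61.1%

Among the compounds with values here, compound 2 holds the higher of the two numbers; its only neighbour is compound 1, and the step of a number 21.5 percentage points higher from compound 1 to compound 2 (beyond the scatter) lies beyond the scatter. That step exchanges 4-methylpiperazin-1-yl for (4-methoxyphenyl)amino and tells nothing about the aryl substituent itself.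

Compound 3, `CCOC(=O)c1c(-c2ccc(Cl)cc2)cc(-c2ccccc2)nc1Nc1ccc(Cl)cc1`, keeps the (4-chlorophenyl)amino pattern of compound 2 and changes only the group on the anilino ring: chloro in place of methoxy on an aromatic carbon. Within the data shown here, no measured step covers a substituent change on that ring, so the numbers give no direction for it. Absent any bearing step, the step of a number 3.1 percentage points lower from compound 2 to compound 3 (within the scatter) is estimated to stay within the scatter. Compound 3 is therefore expected to give about 58% in this assay, in the range 45% to 72%.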

Compound 3, a percentage reported as inhibition, in the whole organism at one dose (the size of the read-out at that dose, not a potency): 40.6%
Beside the measured number, compound 3's estimate is 17.4 percentage points above it, outside the stated range (below it).
By their numbers in this assay, from the lowest: compounds 1 and 3 (each within the scatter of the next); then compound 2.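

In this assay the substituent on the anilino ring proves to count: a number 20.5 percentage points lower from compound 2 to compound 3 (beyond the scatter) comes with chloro in place of methoxy, on an aromatic carbon para to a large group. The (4-methoxyphenyl)amino result therefore does not extend to every arylamino group, since a number 1 percentage points higher from compound 1 to compound 3 (within the scatter) leaves (4-chlorophenyl)amino and 4-methylpiperazin-1-yl indistinguishable in this read-out. No supporting data on hand explain the difference between methoxy and chloro.

Whether methoxy is singular at this place remains open, as the compounds shown do not include a hydroxy group, an amine or a longer alkoxy chain such as ethoxy there. Also open, as far as these compounds go, is whether the methoxy result depends on the ethyl ester of the shared core, which a carboxylic acid or an amide at that place would test.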